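Notes on the 4-methylphenyl to 4-(trifluoromethyl)phenyl step

The source may hold more compounds than are shown below. What is called first, only, known or untested is meant among the compounds shown, and "the series" means these compounds.

Measured so far:
compound 1 `CC(=O)N1N=C(c2ccc(N3CCN(C)CC3)cc2)CC1c1ccc(N(C)C)cc1`: -0.8%
compound 2 `Cc1ccc(S(=O)(=O)N2N=C(c3ccc(N4CCN(C)CC4)cc3)CC2c2ccc(N(C)C)cc2)cc1`: 32.2%

Going by the values given here, in a functional assay on HCC1806 cells (Homo sapiens) for inhibition, read by sulforhodamine B assay, tested at 10 uM (on this read-out lower numbers stand for less inhibition and higher numbers for more inhibition at the one concentration tested (going by the name of the read-out)), compound 2 gives the higher of the two numbers; its nearest neighbour is compound 1, which stands a number 33 percentage points higher from compound 1 to compound 2 (beyond the scatter) away, the sole measured step in the set. That step swaps the group on the ring nitrogen, (4-methylphenyl)sulfonyl in place of acetyl, and is large.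

Compound 3 `CN1CCN(c2ccc(C3=NN(S(=O)(=O)c4ccc(C(F)(F)F)cc4)C(c4ccc(N(C)C)cc4)C3)cc2)CC1` is not yet measured. It keeps the sulfonyl of compound 2 and differs only on its aromatic ring: trifluoromethyl in place of methyl on an aromatic carbon. Among the compounds with values here, no measured step touches a substituent on that ring, so the one known step bears on compound 3 only in that it shows compound 2 carries the nitrogen group with the higher number of the two; it gives no guide to the size of a change out on the aromatic carbon. A small step is therefore expected, a number 2.8 percentage points higher from compound 2 to compound 3 (within the scatter), within the scatter in either direction. Compound 3 is estimated at 35% in this assay, with a range from 15% to 55%.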

Compound 3, a percentage reported as inhibition, at one concentration (the size of the read-out at that concentration, not a potency): 27%
Compound 3: middle estimate off by 8 percentage points, on the high side; measured number inside the range.
By their numbers in this assay, from the lowest: compound 1; then compounds 3 and 2 (each within the scatter of the next).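

Trifluoromethyl in place of methyl on an aromatic carbon, para to a large group, gives the first reading of a change on this ring: in this assay the step is a number 5.2 percentage points lower from compound 2 to compound 3 (within the scatter). Going from one heavy atom to four at this position therefore leaves compound 2 and compound 3 indistinguishable on this read-out, so this pair gives no sign that the read-out responds to this exchange, whereas the change at the ring nitrogen is a large step, a number 33 percentage points higher from compound 1 to compound 2 (beyond the scatter). No measurement that would bear on this result is available for either group.

From the compounds shown here alone, the pair covers only methyl and trifluoromethyl, neither of which has a hydrogen-bond donor, a hydrogen-bond acceptor or a net charge, so it remains open whether an amine, a carboxylic acid or a longer chain on the same aromatic carbon would move the number beyond the scatter. Also open is whether the shared sulfonyl-linked ring needs any group at this carbon, since a plain phenyl ring is not among the compounds shown, and a reading at one concentration does not show how compound 2 and compound 3 would compare at other concentrations.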